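The source may hold more compounds than are shown below. What is called first, only, known or untested is meant among the compounds shown, and "the series" means these compounds.

Compound 1 `Oc1ccc(CNc2ncnc3c2ncn3C2CCCCO2)cc1` was tested in an ADME assay on MCF7 cells (Homo sapiens) for cytotoxicity, with a stated time of 72 h; a higher number here means a weaker inhibitor, a lower number a stronger inhibitor; for compound 1 only a limit of > 100000 nM was obtained. For compound 2 `COc1ccc(CNc2ncnc3c2ncn3C2CCCCO2)cc1` this assay again reports only a limit, > 100000 nM. Compound 3 `COc1cc(CNc2ncnc3c2ncn3C2CCCCO2)ccc1O` likewise reaches only a limit, > 100000 nM. The difference between the cores of compound 1 and compound 2 is methyl in place of hydrogen on an oxygen on an aromatic ring, and its step is a step that the two limits leave unreadable from compound 1 to compound 2. Compound 3 carries methoxy in place of hydrogen on an aromatic carbon relative to compound 1, with the step that the two limits leave unreadable from compound 1 to compound 3; both steps stay unreadable because of the limit of > 100000 nM in this assay, at which 3 of the 3 values shown sit. Compound 4 `COc1ccc(CNc2ncnc3c2ncn3C2CCCCO2)c(OC)c1` has not been measured; it differs from compound 2 by methoxy in place of hydrogen on an aromatic carbon, the same kind of change as from compound 1 to compound 3, but here the entering group sits ortho to a large group and meta to a methoxy group rather than ortho to a hydroxy group and meta to a large group. Compound 4 is expected to show a step that the limit leaves unreadable from compound 2 to compound 4 in this assay, resting on compound 2 giving only > 100000 nM. The estimate for compound 4 is 150000 nM, with a range from 40000 nM to 600000 nM.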

Compound 4, half-maximal inhibitory concentration: > 25000 nM
Compound 4: only a limit was reported (the forecaster's own chance of this, stated with the estimate: 85%); the middle value lies beyond the limit too.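

Compound 4 reaches only a limit of > 25000 nM in this assay, so the step from compound 2 to compound 4 cannot be read. All four compounds shown give only limits, so whether methoxy in place of hydrogen shifts the read-out in this assay stays open.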